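A Methyl on the Saturated Ring, Tried a Second Time

A few compounds are considered here, and "the series" means these few. Any claim that something is new, unique, unknown or untested is made for them only; others in the source may bear on it.

Compound 1 `O=C1NCCN(c2cccc(Br)n2)N1` is the starting point. In a functional assay on cells for inhibition of Polyunsaturated fatty acid 5-lipoxygenase (Homo sapiens) (a higher number here means a weaker inhibitor, a lower number a stronger inhibitor), compound 1 gives 4600 nM. Compound 2 `CC1CN(c2cccc(Br)n2)NC(=O)N1` differs from it by methyl in place of hydrogen on a saturated ring carbon. In this assay compound 2 gives 3100 nM, which amounts to a 1.5-fold lower number from compound 1 to compound 2 (0.17 log units; within the scatter). Compound 3 `COc1cccc(N2CCNC(=O)N2)n1` differs from compound 1 by methoxy in place of bromo on an aromatic carbon. In this assay compound 3 gives 3500 nM, a number within the scatter of compound 1. The unmeasured compound 4 `COc1cccc(N2CC(C)NC(=O)N2)n1` differs from compound 3 by methyl in place of hydrogen on a saturated ring carbon. Among the measured compounds shown here, this is the same kind of change as the one between compound 1 and compound 2, though not the same: here the ring atom two ring bonds away bears a group of 8 heavy atoms, whereas there it bears a group of 7 heavy atoms. For the measured compounds named here, only one measured example of this change exists, the step of a 1.5-fold lower number from compound 1 to compound 2 (0.17 log units; within the scatter), which stayed within the scatter. Compound 4 is therefore expected to show a step of a 1.4-fold lower number from compound 3 to compound 4 (0.15 log units; within the scatter). In this assay compound 4 is estimated at about 2500 nM, with a plausible range from 1200 nM to 5000 nM.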

Compound 4, half-maximal inhibitory concentration: 7100 nM
Beside the measured number, compound 4's estimate is 2.8-fold (0.45 log units) below it; the measured number lies above the stated range.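

In this assay the methyl on the saturated ring carbon brings a 2.0-fold higher number from compound 3 to compound 4 (0.31 log units; beyond the scatter), so this change did not carry over unchanged from the core of compound 1: the same change on two cores in this assay, a 1.5-fold lower number (0.17 log units; within the scatter) from compound 1 to compound 2 and a 2.0-fold higher number (0.31 log units; beyond the scatter) from compound 3 to compound 4, 3.0-fold (0.48 log units) apart, beyond the scatter of two such steps

Read the other way, methoxy in place of bromo brings a 2.3-fold higher number from compound 2 to compound 4 (0.36 log units; beyond the scatter), and this differs from the same swap made without the methyl: the same change on two cores in this assay, a 1.3-fold lower number (0.12 log units; within the scatter) from compound 1 to compound 3 and a 2.3-fold higher number (0.36 log units; beyond the scatter) from compound 2 to compound 4, 3.0-fold (0.48 log units) apart, beyond the scatter of two such steps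

In these four compounds, then, the effect of each change depends on the other, and a step measured on one core did not predict the step on the other; yet this rests on a single pair for each comparison, and it neither explains the difference nor shows how the methyl would behave on any further core.

As far as these compounds go, it remains open whether an ethyl on the same saturated ring carbon would follow the pattern seen with bromo or that seen with methoxy. Also open, from the compounds shown here alone, is how an amine or a nitrile in place of bromo would behave with and without the methyl.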